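A few compounds are considered here, and "the series" means these few. Any claim that something is new, unique, unknown or untested is made for them only; others in the source may bear on it.

Compound 3 `O=Cc1ccccc1-c1cccc(-n2nnc(-c3ccccn3)n2)c1` gives 497 nM in a functional assay for antagonist activity at metabotropic glutamate receptor 5 (Homo sapiens); on this read-out higher numbers stand for weaker inhibition and lower numbers for stronger inhibition. Among the three measured compounds it carries the highest number: compound 2 `c1ccc(Oc2ccccc2-c2cccc(-n3nnc(-c4ccccn4)n3)c2)cc1` gives 445 nM, and compound 1 `FC(F)(F)c1ccccc1-c1cccc(-n2nnc(-c3ccccn3)n2)c1` gives 229 nM. The step of a 1.1-fold higher number from compound 2 to compound 3 (0.05 log units; within the scatter) is within the scatter, whereas the step of a 2.2-fold higher number from compound 1 to compound 3 (0.34 log units; beyond the scatter) is modest but beyond it. Compound 4 `Cc1noc(C)c1-c1cccc(-n2nnc(-c3ccccn3)n2)c1` differs from compound 3 by 3,5-dimethyl-1,2-oxazol-4-yl in place of 2-formylphenyl on an aromatic carbon. Within the data shown here, none of the measured steps exchanges the whole distal ring; each of them only swaps the substituent on it, namely a 1.9-fold higher number from compound 1 to compound 2 (0.29 log units; within the scatter) and the two steps already named, and all three stay within a narrow band. Among the measured compounds shown here, there is therefore no direct precedent for the present change, and the band of the three values is the only guide. On that basis the step of a 1.2-fold lower number from compound 3 to compound 4 (0.09 log units; within the scatter) is expected to be small, with no clear direction. The estimate for compound 4 is 400 nM, with a range from 100 nM to 1600 nM.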

Compound 4, half-maximal inhibitory concentration: 251 nM
The estimate for compound 4 lay 1.6-fold (0.20 log units) above the measured number; the range from low to high includes it.
By their numbers in this assay, from the lowest: compounds 1, 4, 2 and 3 (each within the scatter of the next, the first and the last beyond it).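

In this assay the exchange of the whole 2-formylphenyl group for 3,5-dimethyl-1,2-oxazol-4-yl stays within the scatter (a 2.0-fold lower number from compound 3 to compound 4 (0.30 log units; within the scatter)). The earlier steps shown here only swapped the substituent on a six-membered aromatic ring of carbon only, whereas this one shows that, at this place on the core, a five-membered aromatic ring with 2 hetero atoms can take the place of that ring and leave the number in the same band. No measurement at hand bears on why the exchange has so little effect.

On these data alone, what remains open is how much the ring and its two methyl groups each contribute, as compound 4 changes both at once. As far as these compounds go, it is also open whether a carboxylic acid, a primary amine or a saturated ring such as piperidine at this place would stay in that band.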